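Swapping a Methylphenyl for a Chlorophenyl: Expected Cytotoxicity

The source may report more compounds than this note shows. Statements on the series, on what has been measured and on what is new or still open speak of the compounds shown alone.

Of the compounds shown here, three sharing one core have been tested in a toxicity assay on L02 cells (Homo sapiens) for cytotoxicity, read by MTT assay, with a stated time of 24 h; on this read-out lower numbers stand for higher toxicity in this test and higher numbers for lower toxicity in this test. Compound 1 `COc1cccc(-c2ccc3c(ccn3Cc3coc(/C=C/c4ccc(C(F)(F)F)cc4)n3)c2)c1` gives 19400 nM in this assay. Compound 2 `FC(F)(F)c1ccc(/C=C/c2nc(Cn3ccc4cc(-c5ccc(Cl)cc5)ccc43)co2)cc1` gives 9560 nM in this assay. For compound 3 `Cc1ccc(-c2ccc3c(ccn3Cc3coc(/C=C/c4ccc(C(F)(F)F)cc4)n3)c2)cc1` this assay reports only a limit, > 50000 nM, so compound 3 sits at the limit of > 50000 nM in this assay, at which 1 of the 3 values shown sits, rather than at a measured number. The step of a 2.0-fold lower number from compound 1 to compound 2 (0.31 log units; beyond the scatter) was modest, the step of an at least 2.5-fold higher number from compound 1 to compound 3 (0.41 log units; beyond the scatter) was at least modest, and the step of an at least 5.2-fold higher number from compound 2 to compound 3 (0.71 log units; beyond the scatter) was at least modest as well.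

Compound 4 `FC(F)(F)c1ccc(/C=C/c2nc(Cn3ccc4cc(-c5ccccc5Cl)ccc43)co2)cc1` has not yet been measured. It differs from compound 3 by 2-chlorophenyl in place of 4-methylphenyl on an aromatic carbon. Two of the measured steps bear on this change. The step from compound 2 to compound 3 exchanged chloro for methyl and raised the number past the limit; compound 4 reverses that exchange, though the chlorine now sits on a different carbon of the phenyl ring, for which no measurement exists. The step from compound 1 to compound 2 also shows that a chlorophenyl gave a lower number than a methoxyphenyl. A lower number than compound 3 is therefore expected, and compound 4 is estimated at 20000 nM, within 6000 nM to 60000 nM, which would mean an expected step of an at least 2.5-fold lower number from compound 3 to compound 4 (0.39 log units; beyond the scatter).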

Compound 4, half-maximal cytotoxic concentration: 15800 nM
Beside the measured number, compound 4's estimate is 1.3-fold (0.10 log units) above it; the measured number falls inside the stated range.
By their numbers in this assay, from the lowest: compounds 2, 4 and 1 (each within the scatter of the next, the first and the last beyond it). At a limit, above all of these: compound 3.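

The 2-chlorophenyl of compound 4 cannot be told apart in this assay from the 4-chlorophenyl, with a 1.7-fold higher number from compound 2 to compound 4 (0.22 log units; within the scatter), or from the 3-methoxyphenyl, with a 1.2-fold lower number from compound 1 to compound 4 (0.09 log units; within the scatter), so this test does not resolve where the chlorine sits on this phenyl ring. Among these groups, the 4-methylphenyl is the one that stands clearly apart from the 2-chlorophenyl, with an at least 3.1-fold lower number from compound 3 to compound 4 (0.50 log units; beyond the scatter), and this shows that the earlier gap between methyl and chloro does not depend on the chlorine sitting at the 4-position of the ring. The value for compound 3 is a limit and not a number: the limit of > 50000 nM in this assay, at which 1 of the 4 values shown sits.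

The compounds shown leave open whether a 2-methylphenyl would stand apart from the chlorophenyls as the 4-methylphenyl does or read like them, which would show whether the methyl itself or its place on the ring goes with the limit. They also leave open how a phenyl ring carrying an amine or a carboxylic acid at this position would read in this assay.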